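Swapping the sulfamoyl-thiadiazolyl arm for a nitrophenyl arm

This account rests on a few compounds, and the source may have more. Where it says the series, first, only, none or still open, it means among the compounds named here.

Measured compounds:
compound 1, `CCOC(=O)C1=C(N/C=N/c2nnc(S(N)(=O)=O)s2)Nc2[nH]nc(C)c2C1c1ccc(N(C)C)cc1`, 26300 nM
compound 2, `CCOC(=O)C1=C(N/N=C(/C(=O)Br)c2ccc(Br)cc2)Nc2[nH]nc(C)c2C1c1ccc(N(C)C)cc1`, 68500 nM
compound 3, `CCOC(=O)C1=C(N/N=C(/C(=O)Br)c2ccc(Cl)cc2)Nc2[nH]nc(C)c2C1c1ccc(N(C)C)cc1`, 49300 nM

All three were read in a functional assay on HeLa cells (Homo sapiens) for inhibition, read by MTT assay, with a stated time of 48 h; on this read-out higher numbers stand for weaker inhibition and lower numbers for stronger inhibition. Compound 1 has the lowest of the three numbers, but only the gap to compound 2 counts as real: a 2.6-fold higher number from compound 1 to compound 2 (0.42 log units; beyond the scatter), whereas a 1.9-fold higher number from compound 1 to compound 3 (0.27 log units; within the scatter) and a 1.4-fold lower number from compound 2 to compound 3 (0.14 log units; within the scatter). The shared core of compound 1 is kept in every case; what changes is the arm on the exocyclic nitrogen.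

Compound 4, `CCOC(=O)C1=C(N/C=N/c2ccc([N+](=O)[O-])cc2)Nc2[nH]nc(C)c2C1c1ccc(N(C)C)cc1`, has not yet been measured. It differs from compound 1 in one place:
4-nitrophenyl in place of 5-sulfamoyl-1,3,4-thiadiazol-2-yl on a double-bonded nitrogen

For the measured compounds named here, the steps that bear on this change are those from compound 1 to compounds 2 and 3, where a six-membered carbon-only aromatic ring replaced the five-membered ring with three hetero atoms on the amine nitrogen. Both moved the number upward, one beyond the scatter and one within it, and neither was large. The same direction is therefore expected for compound 4, with a small step rather than a large one.

The estimate for compound 4 in this assay is 38000 nM, between 15000 nM and 95000 nM. That amounts to an expected change of a 1.4-fold higher number from compound 1 to compound 4 (0.16 log units; within the scatter) for compound 4.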

Compound 4, half-maximal inhibitory concentration: 57800 nM
The estimate for compound 4 lay 1.5-fold (0.18 log units) below the measured number, and the stated range covers the measured number.
By their numbers in this assay, from the lowest: compounds 1, 3, 4 and 2 (each within the scatter of the next, the first and the last beyond it).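

In this assay, for the compounds shown here, the earlier steps replaced the whole arm on the amine nitrogen, whereas here the arm is kept up to the double-bonded nitrogen and only the group on that nitrogen changes, giving a 2.2-fold higher number from compound 1 to compound 4 (0.34 log units; beyond the scatter). This shows that replacing 5-sulfamoyl-1,3,4-thiadiazol-2-yl with 4-nitrophenyl at this place is enough on its own to give a step beyond the scatter, although a modest one, while the differently built arms of the halogenated compounds stay level with compound 4 within the scatter: a 1.2-fold higher number from compound 3 to compound 4 (0.07 log units; within the scatter) and a 1.2-fold lower number from compound 2 to compound 4 (0.07 log units; within the scatter). Nothing available here explains the step from compound 1 to compound 4.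

The step removes the sulfamoyl group and the five-membered ring together, so the compounds shown cannot say which of the two goes with the higher number, and a 4-sulfamoylphenyl group at this place would separate them. Also open, as far as these compounds go, is how the number would respond to an amine or a carboxylic acid on the six-membered ring in place of the nitro group.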